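Allyloxy to propoxy: working notes

The source may hold more compounds than are shown below. What is called first, only, known or untested is meant among the compounds shown, and "the series" means these compounds.

- compound 1 `C/C=C/COc1noc2c1CNCC2`: 7.7
- compound 2 `CC#CCOc1noc2c1CNCC2`: 7.6
- compound 3 `C=CCOc1noc2c1CNCC2`: 7.5

In a physicochemical assay for acid dissociation, compound 3 stands within the scatter of the other two compounds, as the steps show (a number 0.20 log units lower from compound 1 to compound 3 (within the scatter); a number 0.10 log units lower from compound 2 to compound 3 (within the scatter)). The next structure is compound 4 `CCCOc1noc2c1CNCC2`, and the change is ethyl in place of vinyl on a saturated chain carbon bound to an oxygen on an aromatic ring (in words, ethyl in place of vinyl, or allyloxy to propoxy). Among the compounds with values here, no measured step replaces this chain with a fully saturated one, so the evidence is indirect. The three changes at this place all stayed small, the remaining one being a number 0.10 log units lower from compound 1 to compound 2 (within the scatter). No step beyond the scatter is therefore expected, the estimated step being a number 0.10 log units higher from compound 3 to compound 4 (within the scatter). For compound 4 the estimated value is 7.6 (expected range 7.3 to 7.9).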

Compound 4, acid dissociation constant: 7.6
Beside the measured number, compound 4's estimate shows no gap at the digits printed; the range from low to high includes it.
By their numbers in this assay, from the lowest: compounds 3, 2, 4 and 1 (each within the scatter of the next).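

In this assay, ethyl in place of vinyl gives the first fully saturated chain at this place, and it stays within the scatter of all three unsaturated chains (a number 0.10 log units higher from compound 3 to compound 4 (within the scatter); no change at the digits printed from compound 2 to compound 4 (within the scatter); a number 0.10 log units lower from compound 1 to compound 4 (within the scatter)). In these four compounds, then, the reading does not depend on the chain holding a double or triple bond. Nothing at hand explains these small steps.

On these data alone, whether a longer chain, a phenyl ring or a terminal amine at this place would also stay within the scatter remains open.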